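The compounds below may be only part of what the source reports. "The series", "measured", "known", "first", "only" and "open" are said of these compounds alone.

Measured so far:
compound 1, `[O-][S+](Cc1ccc(Cl)s1)C(c1ccccc1)c1ccccc1`: 12800 nM
compound 2, `[O-][S+](Cc1cccs1)C(c1ccc(F)cc1)c1ccc(F)cc1`: 4000 nM

In an assay on HEK293 cells for inhibition of sodium-dependent dopamine transporter (Homo sapiens), read by scintillation counting, with stated times of 5 min and 1 min (a lower number here means a stronger inhibitor, a higher number a weaker inhibitor), compound 1 stands at the highest number of the two. Its nearest neighbour is compound 2, which in this assay gives 4000 nM; the gap between them lies beyond the usual scatter, so compound 1 is the weaker of the two on the numbers shown.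

The next compound, compound 3, `Cc1nnc(C[S+]([O-])C(c2ccccc2)c2ccccc2)s1`, differs from compound 1 in one place: 5-methyl-1,3,4-thiadiazol-2-yl in place of 5-chlorothiophen-2-yl on a saturated chain carbon bound to a sulfur. Going by the values given here, no measured pair shows this particular change, so its effect is not known from the data. Compound 3 is expected to fall close to compound 1, with a step of a 1.2-fold higher number from compound 1 to compound 3 (0.07 log units; within the scatter), perhaps toward a slightly higher number but not clearly beyond the scatter. Compound 3 is therefore estimated at 15000 nM, within a range from 5000 nM to 45000 nM.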

Compound 3, half-maximal inhibitory concentration: "not active" (no number reported)
No number was reported for compound 3; the estimate stays without a comparison.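

Going by these compounds alone, compound 3 is reported as not active in this assay with no number, so no step from compound 1 to compound 3 can be read. No other data bear on this result. The compounds shown leave open how far 5-methyl-1,3,4-thiadiazol-2-yl in place of 5-chlorothiophen-2-yl shifts inhibition.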